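The compounds below may be only part of what the source reports. "The series", "measured", "known", "first", "only" and "open" are said of these compounds alone.

Measured so far in a functional assay on the whole organism with Mus musculus as the target; on this read-out higher numbers stand for an effect only at larger amounts of compound and lower numbers for an effect already at smaller amounts (each entry is a limit of the assay, not a number):

Compound 1 (`CN(c1ccncc1)n1cccc1`): > 20 mg/kg
Compound 2 (`CCCN(c1ccncc1)n1cccc1`): > 20 mg/kg
Compound 3 (`CN(c1ccncc1)n1ccc(C=O)c1`): > 20 mg/kg

Compound 3 therefore has no exact place on this scale, only a limit (> 20 mg/kg). The other two compounds stand in the same position, so the whole picture comes down to one observation (the limit of > 20 mg/kg in this assay, at which 3 of the 3 values shown sit).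

Compound 4 (`CCCN(c1ccncc1)n1ccc(C=O)c1`) is compound 3 with a single structural change (ethyl in place of hydrogen on a saturated chain carbon bound to a nitrogen on an aromatic ring): ethyl in place of hydrogen on a saturated chain carbon bound to a nitrogen on an aromatic ring, which is the same as methyl to propyl. The same change has been measured once, on the compound without the formyl group (a step that the two limits leave unreadable from compound 1 to compound 2). The formyl change has also been measured (a step that the two limits leave unreadable from compound 1 to compound 3). With limits at both ends, neither step gives a size or a direction to carry over. Compound 4 combines the two changes, and neither change alone produced a measurable dose. The step expected here (a step that the limit leaves unreadable from compound 3 to compound 4) is thus none that could be read beyond the scatter. For compound 4 the estimated value is 25 mg/kg (expected range 12 mg/kg to 50 mg/kg), and the assay is expected to report most likely only a limit again.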

Compound 4, dose for half-maximal effect: > 20 mg/kg
Compound 4 gave a limit, no number (the forecaster's own chance of this, stated with the estimate: 75%); the middle value does not contradict the limit.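

Among the compounds shown here, compound 4 also gives only a limit (> 20 mg/kg), so no step leading to it from compound 2 or compound 3 can be read, and the picture stays the same: the limit of > 20 mg/kg in this assay, at which 4 of the 4 values shown sit. The compounds shown leave open what dose of any of them gives a half-maximal effect in this assay and whether the ethyl or formyl change alters it.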